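A few compounds are considered here, and "the series" means these few. Any claim that something is new, unique, unknown or untested is made for them only; others in the source may bear on it.

Measured in an ADME assay on MT4 cells (Homo sapiens) for cytotoxicity, read by MTT assay; a lower number here means that less compound is tolerated, a higher number that more compound is tolerated:
- Compound 1 `Cc1ccc(C(=O)N(C(=S)OCCN2C(=O)c3ccccc3C2=O)c2ccc(Cl)cc2)cc1`: > 100000 nM (a limit of the assay, not a number)
- Compound 2 `O=C1c2ccccc2C(=O)N1CCOC(=S)N(C(=O)c1cccc(F)c1F)c1ccc(Cl)cc1`: 58000 nM
- Compound 3 `O=C1c2ccccc2C(=O)N1CCOC(=S)N(C(=O)c1cc(F)cc(F)c1)c1ccc(Cl)cc1`: 59000 nM

Compound 3, at 59000 nM, stands level with compound 2, as the step between them shows: a 1.0-fold higher number from compound 2 to compound 3 (0.01 log units; within the scatter). Going by the values given here, these are the only two exact numbers in this assay.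

Compound 4 `O=C1c2ccccc2C(=O)N1CCOC(=S)N(C(=O)c1cccc(Cl)c1Cl)c1ccc(Cl)cc1` has not yet been measured. It carries 2,3-dichlorophenyl in place of 3,5-difluorophenyl on a carbonyl carbon.

Among the compounds with values here, no measured step swaps fluorine for chlorine, so the evidence is indirect. Moving the two fluorines made no difference beyond the scatter: a 1.0-fold higher number from compound 2 to compound 3 (0.01 log units; within the scatter). The other two steps, an at least 1.7-fold lower number from compound 1 to compound 2 (0.23 log units; that floor lies within the scatter) and an at least 1.6-fold lower number from compound 1 to compound 3 (0.22 log units; that floor lies within the scatter), start from a limit and also stay within the scatter.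

No change beyond the scatter is therefore expected, and the estimated step is small: a 1.1-fold lower number from compound 3 to compound 4 (0.03 log units; within the scatter). The estimate for compound 4 is 55000 nM, with an expected range from 28000 nM to 100000 nM.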

Compound 4, half-maximal cytotoxic concentration: 54000 nM
Compound 4: middle estimate off by 1.0-fold (0.01 log units), on the high side, and the stated range covers the measured number.
By their numbers in this assay, from the lowest: compounds 4, 2 and 3 (each within the scatter of the next). At a limit, above all of these: compound 1.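

In this assay, the group on the carbonyl carbon can now carry chlorine as well as fluorine with no shift beyond the scatter: 2,3-dichlorophenyl in place of 3,5-difluorophenyl gives a 1.1-fold lower number from compound 3 to compound 4 (0.04 log units; within the scatter) and stays level. Going by these compounds alone, the swap of 2,3-difluorophenyl for 2,3-dichlorophenyl is the first direct comparison of the two halogens at this position, and it gives a 1.1-fold lower number from compound 2 to compound 4 (0.03 log units; within the scatter) with the same outcome. The step of an at least 1.8-fold lower number from compound 1 to compound 4 (0.26 log units; that floor lies within the scatter) starts from a limit, so it gives only a floor: the limit of > 100000 nM in this assay, at which 1 of the 4 values shown sits.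

The compounds shown leave open whether a phenyl ring bearing an amine or a carboxylic acid on this carbonyl carbon would move the number beyond the scatter. A simple alkyl chain in place of the ring is equally untested here.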